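This account rests on a few compounds, and the source may have more. Where it says the series, first, only, none or still open, it means among the compounds named here.

Compound 1 `Cc1ccccc1C(=O)NC1CCN(c2ncnc3[nH]ncc23)CC1` gives 6260 nM in an assay on isolated protein for inhibition of serine/threonine-protein kinase PAK 1 (Homo sapiens), read by ADP-Glo, with a stated time of 40 min; a lower number here means a stronger inhibitor, a higher number a weaker inhibitor.
Compound 2 `O=C(NC1CCN(c2ncnc3[nH]ncc23)CC1)c1cccc(C(F)(F)F)c1` gives 2510 nM in this assay.
Compound 3 `O=C(NC1CCN(c2ncnc3[nH]ncc23)CC1)c1cccc(Cl)c1Cl` gives 4170 nM in this assay.

Compound 3 stands second highest of these three numbers, and its value lies within the scatter of both compound 1 and compound 2. The change to compound 4 `COc1ccc(NC(=O)NC2CCN(c3ncnc4[nH]ncc34)CC2)cc1` is (4-methoxyphenyl)amino in place of 2,3-dichlorophenyl on a carbonyl carbon. Going by the values given here, the only measured step at the same place, a 1.5-fold lower number from compound 1 to compound 3 (0.18 log units; within the scatter), stayed within the scatter, and the values of compound 2 and compound 3 likewise differ by no more than the scatter. Among the compounds with values here, no measured step exchanges an aryl group for an arylamino group, so nothing shows whether that exchange matters. Compound 4 is therefore expected to show a 1.0-fold lower number from compound 3 to compound 4 (0.02 log units; within the scatter), no step beyond the scatter. Compound 4 is estimated at 4000 nM, within 1300 nM to 12000 nM.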

Compound 4, half-maximal inhibitory concentration: 6370 nM
Estimate against measurement, compound 4: 1.6-fold (0.20 log units) below; the range from low to high includes it.
By their numbers in this assay, from the lowest: compounds 2, 3, 1 and 4 (each within the scatter of the next, the first and the last beyond it).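

In this assay, going by these compounds alone, the first exchange of an aryl group for an arylamino group at this carbonyl carbon gives a 1.5-fold higher number from compound 3 to compound 4 (0.18 log units; within the scatter), and the exchange from the 2-methylphenyl group gives a 1.0-fold higher number from compound 1 to compound 4 (0.01 log units; within the scatter). Neither step leaves the scatter, so (4-methoxyphenyl)amino, with its added hydrogen-bond donor, is tolerated here without a measurable step from either aryl group. Nothing available bears on why this is so. Still open, going by these compounds, is whether an aliphatic amine or a carboxylic acid in place of these groups would give a step beyond the scatter. On these data alone, whether a longer chain at this carbonyl carbon would do so is also open.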